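Heteroaryl amide in place of a lactam on the thiophene core

The source may report more compounds than this note shows. Statements on the series, on what has been measured and on what is new or still open speak of the compounds shown alone.

The study concerns positive allosteric modulators measured in an assay on cells for positive allosteric modulation of Cystic fibrosis transmembrane conductance regulator variant F508del (Homo sapiens), with stated times of 10 min and 7 s, in the presence of a further agent that is not named here; a lower number here means that less compound is needed, a higher number that more compound is needed for the effect. Of the compounds shown here, two have numbers so far. Compound 1, `CC1Cc2c(sc(NC(=O)c3ccccc3O)c2C(N)=O)C(C)O1`, gives 4 nM in this assay. Compound 2, `CC1(C)Cc2c(sc(NC(=O)C3CNC(=O)C3)c2C(N)=O)C(C)(C)O1`, is a different matter: in this assay compound 2 gives only > 10000 nM, which is a limit of the assay and not a number, as noted in the limit of > 10000 nM in this assay, at which 1 of the 2 values shown sits. For the measured compounds named here, compound 2 therefore stands at the weak end of what has been measured, and no step between it and compound 1 can be stated, since the two differ in more than one place.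

The next compound, compound 3, `Cc1cn[nH]c1C(=O)Nc1sc2c(c1C(N)=O)CC(C)(C)OC2(C)C`, is to be measured in this assay. It differs from compound 2 in one place: 4-methyl-1H-pyrazol-5-yl in place of 5-oxopyrrolidin-3-yl on a carbonyl carbon. The aromatic amide substituent brings compound 3 closer in character to compound 1 than compound 2 was, so a step in the direction of less compound needed is expected from compound 2 to compound 3, of size an at least 12-fold lower number from compound 2 to compound 3 (1.09 log units; beyond the scatter), well beyond the scatter. For compound 3 the estimate in this assay is 800 nM, with a range from 60 nM to 10000 nM.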

Compound 3, half-maximal effective concentration: 2 nM
Beside the measured number, compound 3's estimate is 400-fold (2.60 log units) above it; the whole stated range lies above it.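

Exchanging 5-oxopyrrolidin-3-yl for 4-methyl-1H-pyrazol-5-yl on a carbonyl carbon, with the rest of the molecule unchanged, gives in this assay an at least 5000-fold lower number from compound 2 to compound 3 (3.69 log units; beyond the scatter), which shows that the outcome in this assay depends strongly on this one position. The two groups have the same number of heavy atoms, hydrogen-bond donors and hydrogen-bond acceptors and carry no net charge, so these counts do not separate them, whereas a five-membered aromatic ring with 2 hetero atoms takes the place of a five-membered non-aromatic ring with 1 hetero atom. The full size of the step stays unknown, since compound 2 stands at a limit of the assay and not at a number: the limit of > 10000 nM in this assay, at which 1 of the 3 values shown sits.

The compounds shown leave open how much of the step belongs to the methyl group of 4-methyl-1H-pyrazol-5-yl, a question that an unsubstituted 1H-pyrazol-5-yl or an ethyl group in place of the methyl would bear on. For the compounds shown here, they also leave open whether the aromatic ring alone suffices or its ring nitrogens are needed, which a phenyl or furyl group on the same carbonyl carbon would address, and no step to compound 1 can be read, since it differs from the other compounds in more than one place.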